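Swapping a side chain on compound 2

The source may hold more compounds than are shown below. What is called first, only, known or untested is meant among the compounds shown, and "the series" means these compounds.

Compound 1 `COc1cc(N2C(=O)C3(CCC3)N(c3ccc(OC4CCN(C)CC4)nc3)C2=S)cnc1C#N` gives 116%
Compound 2 `CN1CCC(Oc2ccc(N3C(=S)N(c4cnc(C#N)c(C(F)(F)F)c4)C(=O)C34CCC4)cc2)CC1` gives 56%
Compound 3 `CN1CCC(Oc2ccc(N3C(=S)N(c4cnc(C#N)c(C(F)(F)F)c4)C(=O)C34CCC4)cn2)CC1` gives 56%

In an ADME assay on the whole organism (Mus musculus, strain CD1) for pharmacokinetics, at a dose of 10 mg/kg by the oral route (a higher number here means that a larger share of the oral dose reaches the circulation, a lower number that a smaller share of the oral dose reaches the circulation), compound 2 stands level with compound 3, and the two share the lowest number of the three. Compound 4 `N#Cc1ncc(N2C(=O)C3(CCC3)N(c3ccc(CN4CCNCC4)cc3)C2=S)cc1C(F)(F)F` changes one side chain of compound 2 ((piperazin-1-yl)methyl in place of (1-methylpiperidin-4-yl)oxy on an aromatic carbon), with (piperazin-1-yl)methyl in place of (1-methylpiperidin-4-yl)oxy on an aromatic carbon. Among the measured compounds shown here, the one measured step (a number 60 percentage points lower from compound 1 to compound 3 (beyond the scatter)) was large, but it exchanges methoxy for trifluoromethyl, a group that compound 2 and compound 4 both carry. For the measured compounds named here, no measured step touches this side chain, so no step beyond the scatter is expected, and the range stays wide. The estimated change is small (a number 8 percentage points lower from compound 2 to compound 4 (within the scatter)). For compound 4 the expected value is 48% (expected range 20% to 75%).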

Compound 4, oral bioavailability: 97%
Beside the measured number, compound 4's estimate is 49 percentage points below it; the measured number lies above the stated range.
By their numbers in this assay, from the lowest: compounds 2 and 3 (each within the scatter of the next); then compound 4; then compound 1.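

In this assay there is a number 41 percentage points higher from compound 2 to compound 4 (beyond the scatter) when (piperazin-1-yl)methyl takes the place of (1-methylpiperidin-4-yl)oxy on this aromatic carbon, para to a large group. The side chain at this position can therefore move the number beyond the scatter, something the earlier step, which exchanged a different group, could not show. Nothing measured here bears on the reason for this rise.

This change swaps the ring and its link to the aromatic carbon together, and the compounds shown do not separate the two. A (morpholin-4-yl)methyl group at this position would show how much depends on the piperazine ring itself.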